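A few compounds are considered here, and "the series" means these few. Any claim that something is new, unique, unknown or untested is made for them only; others in the source may bear on it.

Compound 1 `COc1cc2cc(Cc3ccc(O)cc3)c(=O)oc2cc1O` gives 69500 nM in a functional assay on HeLa cells (Homo sapiens) for cytotoxicity, read by MTT assay, with a stated time of 72 h; on this read-out higher numbers stand for weaker inhibition and lower numbers for stronger inhibition. Compound 2 `COc1ccc(CCC(=O)c2ccc(O)cc2)c(OC)c1` gives > 100000 nM in this assay, and that value is a limit of the assay rather than a number. It sits at the limit of > 100000 nM in this assay, at which 1 of the 2 values shown sits. Compound 3 `COc1ccc(CCC(=O)c2ccc(O)cc2)c(O)c1` differs from compound 2 in a single place: hydrogen in place of methyl on an oxygen on an aromatic ring. Among the compounds with values here, no measured pair differing in one place is available to gauge this change, so the expected step of a number no higher from compound 2 to compound 3 (the limit leaves the size open) is small, not beyond the usual scatter, and could run in either direction. Compound 3 is therefore expected to give about 100000 nM, somewhere within 50000 nM to 250000 nM.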

Compound 3, half-maximal inhibitory concentration: 46100 nM
Beside the measured number, compound 3's estimate is 2.2-fold (0.34 log units) above it; measured number outside the range, below it.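

Within the data shown here, replacing methoxy with hydroxy on the aromatic ring gives an at least 2.1-fold lower number from compound 2 to compound 3 (0.33 log units; beyond the scatter) in this assay, the first single-change comparison. This one change is enough to shift the read-out beyond the usual scatter, toward stronger inhibition. Only a minimum size can be given for the step, because the value of compound 2 is a limit of the assay: the limit of > 100000 nM in this assay, at which 1 of the 3 values shown sits.

From the compounds shown here alone, how an ethoxy group or an amine would compare at this place remains open. So does whether the same change at the remaining methoxy of compound 3 would have a similar effect.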